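Solubility notes: amide series, aryl change on the chain carbon

The source may hold more compounds than are shown below. What is called first, only, known or untested is meant among the compounds shown, and "the series" means these compounds.

Measured compounds:
- Compound 1 `CNC(=O)c1cc(C(=O)NC2CC2)cn(Cc2cccc3[nH]ccc23)c1=O`: 17 ug/mL
- Compound 2 `CNC(=O)c1cc(C(=O)NC2CCC2)cn(Cc2ccccn2)c1=O`: 920 ug/mL
- Compound 3 `CNC(=O)c1cc(C(=O)NC2CCC2)cn(Cc2ccncc2)c1=O`: 121 ug/mL

In a physicochemical assay for solubility, read by HPLC, in simulated intestinal fluid, with a stated time of 16 h, tested at 125 ug/mL (a higher number here means a more soluble compound, a lower number a less soluble compound), compound 1 gives 17 ug/mL, the lowest of the three numbers. Compound 3 is nearest to it with 121 ug/mL, and compound 2 is furthest with 920 ug/mL. Going by the values given here, the one step that compares two measured compounds directly is a 7.6-fold lower number from compound 2 to compound 3 (0.88 log units; beyond the scatter); it concerns a shift between two pyridyl groups on the saturated chain carbon bound to the aromatic nitrogen and does not touch the groups at issue here.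

Compound 4 `CNC(=O)c1cc(C(=O)NC2CC2)cn(Cc2cccc3occc23)c1=O` is not yet measured in this assay. It differs from compound 1 in one place: 1-benzofuran-4-yl in place of 1H-indol-4-yl on a saturated chain carbon bound to an aromatic nitrogen. Among the compounds with values here, no measured step in this set bears on that exchange, so the expectation rests on compound 1 alone, with 17 ug/mL as the anchor. The step expected in this assay is none beyond the scatter, leaning slightly toward a lower number, so that compound 4 is estimated at a 1.4-fold lower number from compound 1 to compound 4 (0.15 log units; within the scatter). The estimate for compound 4 in this assay is 12 ug/mL, with a range from 4 ug/mL to 40 ug/mL.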

Compound 4, solubility: 74 ug/mL
Compound 4: middle estimate off by 6.2-fold (0.79 log units), on the low side; the whole stated range lies below it.
By their numbers in this assay, from the lowest: compound 1; then compounds 4 and 3 (each within the scatter of the next); then compound 2.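

In this assay the exchange of 1H-indol-4-yl for 1-benzofuran-4-yl gives a 4.4-fold higher number from compound 1 to compound 4 (0.64 log units; beyond the scatter) on a saturated chain carbon bound to an aromatic nitrogen. Going by these compounds alone, the number at this position therefore moves with a single hetero atom exchange in the five-membered aromatic ring, where the hydrogen-bond donor of 1H-indol-4-yl gives way to the hydrogen-bond acceptor of 1-benzofuran-4-yl, whereas the earlier step covered only two pyridyl groups. No supporting data bear on what lies behind this step.

From the compounds shown here alone, whether the hetero atom itself or the loss of the donor drives the step stays open, as does whether the step would recur with the cyclobutyl amide of compound 2 and compound 3. Also open, going by these compounds, is how a carboxylic acid or a dimethylamino group on the 1-benzofuran-4-yl group would read out.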